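The source may report more compounds than this note shows. Statements on the series, on what has been measured and on what is new or still open speak of the compounds shown alone.

Measured compounds:
- Compound 1 `Cc1noc(C)c1-c1cnc(N)c(Oc2ccc(C(=O)NC3CCCC3)cc2)n1`: 25200 nM
- Compound 2 `Cc1noc(C)c1-c1cnc(N)c(Oc2ccc(C(=O)Nc3ccccc3)cc2)n1`: 5740 nM

In a functional assay on LoVo cells (Homo sapiens) for inhibition, read by MTT assay, with a stated time of 72 h (a lower number here means a stronger inhibitor, a higher number a weaker inhibitor), compound 1 gives 25200 nM, the highest of the two numbers; its nearest neighbour is compound 2, with a 4.4-fold lower number from compound 1 to compound 2 (0.64 log units; beyond the scatter). Compound 3 `Cc1noc(C)c1-c1cnc(N)c(Oc2ccc(C(=O)Nc3ccccc3Cl)cc2)n1` differs from compound 1 by 2-chlorophenyl in place of cyclopentyl on an amide-type nitrogen. Within the data shown here, the one step that bears on this is the step from compound 1 to compound 2, which swapped the same cyclopentyl for a plain phenyl and gave a modest drop. A comparable step is therefore expected here, a 5.0-fold lower number from compound 1 to compound 3 (0.70 log units; beyond the scatter), towards a lower number. Compound 3 is estimated at 5000 nM, with a range of 1500 nM to 16000 nM.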

Compound 3, half-maximal inhibitory concentration: > 100000 nM
Compound 3: no number, only a limit; the forecaster's own chance of this, stated with the estimate: 3%; at least 20-fold (1.30 log units) between middle value and limit.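

In this assay compound 3 gives only a limit, not a number: the limit of > 100000 nM in this assay, at which 1 of the 3 values shown sits. Chloro in place of hydrogen on the aromatic ring gives an at least 17-fold higher number from compound 2 to compound 3 (1.24 log units; beyond the scatter), a large loss of activity from a single added atom. Set against the cyclopentyl amide, the change gives an at least 3.9-fold higher number from compound 1 to compound 3 (0.59 log units; beyond the scatter), so the gain that phenyl brought over cyclopentyl does not survive this chloro.

As far as these compounds go, whether a fluoro or a methyl group in place of that chloro would cost as much remains open. So does the effect of an amine there.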